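The source may report more compounds than this note shows. Statements on the series, on what has been measured and on what is new or still open speak of the compounds shown alone.

Measured compounds in this series:

compound 1, `Cc1ccc(NC(=O)N2CCN(c3ncccc3C(F)(F)F)CC2)cc1`, 1550 nM
compound 2, `O=C(Nc1ccc(Oc2ccccc2)cc1)N1CCN(c2ncccc2C(F)(F)F)CC1`, 916 nM
compound 3, `CC(C)c1ccc(NC(=O)N2CCN(c3ncccc3Br)CC2)cc1`, 27.1 nM

In a functional assay on HEK293 cells for antagonist activity at transient receptor potential cation channel subfamily V member 1 (Rattus norvegicus) (a higher number here means a weaker inhibitor, a lower number a stronger inhibitor), compound 3 gives the lowest number of the three; its gaps to compound 2 and to compound 1 are both well beyond the scatter, so it is the strongest inhibitor among the measured compounds. Compound 1 and compound 2 differ only on the aryl side of the urea, and that step, a 1.7-fold lower number from compound 1 to compound 2 (0.23 log units; within the scatter), is small. Among the measured compounds shown here, compound 3 differs from both of them in two places at once, on the aryl side and on the pyridine; no single step isolates either change, so what the bromo contributes cannot be read off.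

Compound 4, `CC(C)c1ccc(NC(=O)N2CCN(c3ncccc3C(F)F)CC2)cc1`, keeps the aryl side of compound 3 and alters the pyridine: difluoromethyl in place of bromo on an aromatic carbon. For the measured compounds named here, no measured step touches this position, and the one measured step, on the aryl side, is within the scatter and does not bear on it. Going by the values given here, with no direct precedent, the expectation rests on compound 3 alone, with a modest loss allowed for an exchange at this position.

Compound 4 is therefore expected to give about 45 nM in this assay, within a range of 15 nM to 150 nM; the expected step is a 1.7-fold higher number from compound 3 to compound 4 (0.22 log units; within the scatter).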

Compound 4, half-maximal inhibitory concentration: 61.5 nM
Compound 4: middle estimate off by 1.4-fold (0.14 log units), on the low side, within the range that was stated.
By their numbers in this assay, from the lowest: compound 3; then compound 4; then compounds 2 and 1 (each within the scatter of the next).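

With the aryl side held fixed, the pyridine position gets its first direct reading in this assay: a 2.3-fold higher number from compound 3 to compound 4 (0.36 log units; beyond the scatter). The earlier compounds shown here could not separate this position from the aryl side, whereas this pair shows that the number responds to the change from 3-bromopyridin-2-yl to 3-(difluoromethyl)pyridin-2-yl, even though neither group adds a hydrogen-bond donor, a hydrogen-bond acceptor or a net charge, and that compound 4 keeps a number of 61.5 nM after the exchange. Nothing measured on these compounds accounts for the size or direction of this step, so it stands as an observation on one pair.

As far as these compounds go, whether the step carries over to another aryl side remains open, and the steps that would separate the aryl side from the pyridine position cannot be read, as trifluoromethyl appears at this position only with the aryl sides of compound 1 and compound 2. Also open, from the compounds shown here alone, is how trifluoromethyl, a nitrile or a methoxy group would compare with bromo at this position on the aryl side of compound 3.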